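The compounds below may be only part of what the source reports. "The series", "measured", "known", "first", "only" and "open" are said of these compounds alone.

Measured in a functional assay on HepG2 cells (Homo sapiens) for inhibition, read by fluorescence and resazurin assay, with a stated time of 72 h; a lower number here means a stronger inhibitor, a higher number a weaker inhibitor:
Compound 1 `Cc1cnc(Nc2cccc(NC(=O)Nc3ccccc3)c2)nc1Nc1ccc2cn[nH]c2c1`: 3600 nM
Compound 2 `O=C(Nc1ccccc1)Nc1cccc(Nc2ncc(Cl)c(Nc3ccc4cn[nH]c4c3)n2)c1`: 3500 nM
Compound 3 `O=C(Nc1ccccc1)Nc1cccc(Nc2ncc([N+](=O)[O-])c(Nc3ccc4cn[nH]c4c3)n2)c1`: > 25000 nM

Compound 3 gives > 25000 nM, which is a limit of the assay and not a number. Compound 4 `Nc1cnc(Nc2cccc(NC(=O)Nc3ccccc3)c2)nc1Nc1ccc2cn[nH]c2c1` carries amino in place of nitro on an aromatic carbon. Among the measured compounds shown here, three measured steps bear on this change. Chloro in place of methyl gave a 1.0-fold lower number from compound 1 to compound 2 (0.01 log units; within the scatter), while nitro gave an at least 6.9-fold higher number from compound 1 to compound 3 (0.84 log units; beyond the scatter) and an at least 7.1-fold higher number from compound 2 to compound 3 (0.85 log units; beyond the scatter). For the measured compounds named here, no measured compound carries amino, so the expectation is loose, but it points back towards compound 1 and compound 2 in this assay. An estimated at least 4.1-fold lower number from compound 3 to compound 4 (0.61 log units; beyond the scatter) is therefore expected, in the direction of a lower number. For compound 4 the expected value is 6000 nM, with an estimated range from 2000 nM to 20000 nM.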

Compound 4, half-maximal inhibitory concentration: > 25000 nM
Compound 4 gave a limit, no number (the forecaster's own chance of this, stated with the estimate: 15%); at least 4.1-fold (0.61 log units) between middle value and limit.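

In this assay compound 4 gives > 25000 nM, which is a limit of the assay and not a number. Amino in place of methyl gives an at least 6.9-fold higher number from compound 1 to compound 4 (0.84 log units; beyond the scatter), and amino in place of chloro gives an at least 7.1-fold higher number from compound 2 to compound 4 (0.85 log units; beyond the scatter), so at this position amino, like nitro, does not match methyl or chloro. The step between compound 3 and compound 4 cannot be read, because both sit at the same limit: the limit of > 25000 nM in this assay, at which 2 of the 4 values shown sit.

As far as these compounds go, whether fluoro, methoxy or a nitrile here would stay level with compound 1 and compound 2 remains open. So does the true potency of compound 3 and compound 4.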